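The source may report more compounds than this note shows. Statements on the series, on what has been measured and on what is new or still open speak of the compounds shown alone.

Compound 2 `Nc1ncnc2c1c(Oc1cc(C(F)(F)F)ccn1)nn2C1CC1` carries a cyclopropyl group on the aromatic nitrogen. In an ADME assay on microsomes from liver (Homo sapiens) for metabolic stability, read by LC-MS, using NADPH, with a stated time of 10 min, tested at 10 uM (a higher number here means that the compound lasts longer, a lower number that the compound disappears faster), compound 2 gives > 2.41 h, which is a limit of the assay rather than a number (the limit of > 2.41 h in this assay, at which 1 of the 2 values shown sits). Compound 1 `Nc1ncnc2c1c(Oc1cc(C(F)(F)F)ccn1)nn2C1CCC1` gives 1.02 h in this assay. Among the measured compounds shown here, the only measured step, an at least 2.3-fold higher number from compound 1 to compound 2 (0.37 log units; beyond the scatter), shows the smaller ring lasting longer. Compound 3 `Nc1ncnc2c1c(Oc1cc(C(F)(F)F)ccn1)nn2[C@@H]1CCCC[C@H]1O` brings (2-hydroxycyclohexyl in place of cyclopropyl on an aromatic nitrogen). For the measured compounds named here, no measured step covers a hydroxyl-bearing ring, and compound 2 sits at a limit, so the starting point is uncertain; a modest downward step is expected, an at least 1.6-fold lower number from compound 2 to compound 3 (0.20 log units; that floor lies within the scatter). Compound 3 is expected at 1.5 h, within 0.5 h to 4 h.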

Compound 3, half-life in the Homo sapiens assay: > 2.41 h
Compound 3: a limit, no number (the forecaster's own chance of this, stated with the estimate: 25%); middle value at least 1.6-fold (0.20 log units) from the limit.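

In the Homo sapiens assay a larger ring on the aromatic nitrogen need not mean a shorter half-life, since compound 3, with its 2-hydroxycyclohexyl group, shows an at least 2.3-fold higher number from compound 1 to compound 3 (0.37 log units; beyond the scatter). Compound 3 gives a limit of the assay, as compound 2 does, so the step between them cannot be read. In a physicochemical assay for solubility, read by HPLC, in phosphate buffer, measured as kinetic solubility, with a stated time of 24 h, at pH 7.4 (on this read-out higher numbers stand for higher solubility and lower numbers for lower solubility), compound 2 gives 191000 nM and compound 3 gives 92700 nM, which is a 2.1-fold lower number from compound 2 to compound 3 (0.31 log units; beyond the scatter).

Going by these compounds, the order of compound 2 and compound 3 in half-life stays open. Also open, on these data alone, is whether the ring or its hydroxyl carries the change, and what an amine in place of that hydroxyl would give.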